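This account rests on a few compounds, and the source may have more. Where it says the series, first, only, none or still open, it means among the compounds named here.

Measured so far in an ADME assay for permeability, using PAMPA, with a stated time of 30 min, at pH 7.4; on this read-out higher numbers stand for higher permeability and lower numbers for lower permeability:
Compound 1, `COc1ccc(F)cc1CNCCCNc1ccnc2cc(CCc3ccccc3)ccc12`, gives 23 10^-6 cm/s.
Compound 2, `COc1ccc(F)cc1CNCCCNc1ccnc2cc(-c3cccc4ccccc34)ccc12`, gives 237 10^-6 cm/s.

Compound 2 stands highest of these two, with compound 1 a large step below it, as a 10-fold higher number from compound 1 to compound 2 (1.01 log units; beyond the scatter) shows. Compound 3, `COc1ccc(F)cc1CNCCCNc1ccnc2cc(Oc3ccc(F)cc3)ccc12`, differs from compound 2 only at this aromatic carbon: 4-fluorophenoxy in place of naphthalen-1-yl on an aromatic carbon. Within the data shown here, the one measured step that bears on it is the change at this same carbon from compound 1 to compound 2, which was large; it shows that the group here can move this assay a long way. A smaller group entering in place of naphthalen-1-yl is therefore expected to give a clear downward step, a 3.0-fold lower number from compound 2 to compound 3 (0.47 log units; beyond the scatter), though not down to compound 1. Compound 3 is estimated at 80 10^-6 cm/s, within 30 10^-6 cm/s to 220 10^-6 cm/s.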

Compound 3, apparent permeability: 317 10^-6 cm/s
Beside the measured number, compound 3's estimate is 4.0-fold (0.60 log units) below it; the whole stated range lies below it.
By their numbers in this assay, from the lowest: compound 1; then compounds 2 and 3 (each within the scatter of the next).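

In this assay, the change of group at this aromatic carbon gives a 1.3-fold higher number from compound 2 to compound 3 (0.13 log units; within the scatter), so 4-fluorophenoxy and naphthalen-1-yl cannot be told apart here, although one has a single ring plus an oxygen and a fluorine and the other has two rings of carbon only. With 4-fluorophenoxy in place of phenethyl, the result is a 14-fold higher number from compound 1 to compound 3 (1.14 log units; beyond the scatter), so the large step first seen with naphthalen-1-yl now appears with a second, different group. Open, on these data alone, is whether an amine or a carboxylic acid at this carbon would read like these groups or like phenethyl. Nothing measured here explains why phenethyl stands apart from the other two.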